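Cyclobutyl to ethyl on the amide carbonyl, two sites

This account rests on a few compounds, and the source may have more. Where it says the series, first, only, none or still open, it means among the compounds named here.

Compound 1 `CCC(=O)NCCCO[C@H]1[C@H](C)O[C@@H](O[C@H]2[C@H](C)[C@@H](O[C@@H]3O[C@H](C)C[C@H](N(C)C)[C@H]3O)[C@](C)(O)C[C@@H](C)CN(C)[C@H](C)[C@@H](O)[C@](C)(O)[C@@H](CC)OC(=O)[C@@H]2C)C[C@@]1(C)OC`, compound 2 `CC[C@H]1OC(=O)[C@H](C)[C@@H](O[C@H]2C[C@@](C)(OC)[C@@H](OCCCNC(=O)C3CCC3)[C@H](C)O2)[C@H](C)[C@@H](O[C@@H]2O[C@H](C)C[C@H](N(C)C)[C@H]2O)[C@](C)(O)C[C@@H](C)CN(C)[C@H](C)[C@@H](O)[C@]1(C)O` and compound 3 `CC[C@H]1OC(=O)[C@H](C)[C@@H](O[C@H]2C[C@@](C)(OC)[C@@H](O)[C@H](C)O2)[C@H](C)[C@@H](O[C@@H]2O[C@H](C)C[C@H](N(C)C)[C@H]2OCCCNC(=O)C2CCC2)[C@](C)(O)C[C@@H](C)CN(C)[C@H](C)[C@@H](O)[C@]1(C)O` have been measured in a physicochemical assay for lipophilicity, read by HPLC, measured as chromatographic lipophilicity, at pH 7.4; a lower number here means a more polar compound, a higher number a more lipophilic compound; compound 4 `CCC(=O)NCCCO[C@H]1[C@H](O[C@@H]2[C@@H](C)[C@H](O[C@H]3C[C@@](C)(OC)[C@@H](O)[C@H](C)O3)[C@@H](C)C(=O)O[C@H](CC)[C@@](C)(O)[C@H](O)[C@@H](C)N(C)C[C@H](C)C[C@@]2(C)O)O[C@H](C)C[C@@H]1N(C)C` has not. In this assay compound 1 gives 2.54, compound 2 gives 2.62 and compound 3 gives 3.16.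

Compound 2 and compound 1 differ in one place: ethyl in place of cyclobutyl on a carbonyl carbon. This change gives a number 0.08 log units lower from compound 2 to compound 1 (within the scatter), so the two values are treated as the same.

Compound 3 carries the same atoms as compound 2, joined differently; the difference between the two cores is not broken down here. Its value in this assay is higher than those of compound 1 and compound 2, and both gaps are beyond the scatter.

Compound 4 differs from compound 3 in the same way as compound 1 from compound 2: ethyl in place of cyclobutyl on a carbonyl carbon. The place is the same in both pairs, so the same change is made on the core of compound 3.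

The step from compound 3 to compound 4 is expected to be a number 0.08 log units lower from compound 3 to compound 4 (within the scatter), resting on the earlier pair, where the same change gave a number 0.08 log units lower from compound 2 to compound 1 (within the scatter) and stayed within the scatter. Compound 4 is therefore expected to give about 3.08 in this assay, with a range from 2.75 to 3.4.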

Compound 4, distribution coefficient: 2.7
Estimate against measurement, compound 4: 0.38 log units above, and the stated range ends above it.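

In this assay the change of cyclobutyl to ethyl on a carbonyl carbon gives a number 0.46 log units lower from compound 3 to compound 4 (beyond the scatter) and so lies beyond the scatter, while the same change on the other core gives a number 0.08 log units lower from compound 2 to compound 1 (within the scatter) and stays within the scatter. The size of this step therefore did not carry over from one core to the other, and a step read on one of these two cores is a poor guide to the same change on the other, although this rests on a single pair for each core and does not show how the change would behave on any further core. Nothing available bears on why the two pairs part in this way.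

Only cyclobutyl and ethyl are shown on this carbonyl carbon, so it remains open whether a longer chain, an amine or a carboxylic acid in that place would also give steps that part between the two cores. It also remains open whether the larger step seen with compound 4 would recur in other pairs on that core, or belongs to this one pair alone.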